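The source may report more compounds than this note shows. Statements on the series, on what has been measured and on what is new or still open speak of the compounds shown alone.

In a functional assay on K562 cells (Homo sapiens) for inhibition, read by fluorescence, with a stated time of 72 h (a lower number here means a stronger inhibitor of growth, a higher number a weaker inhibitor of growth), compound 1 (`CC(C)CCn1cnc2c(Nc3ccc(Cl)cc3)nc(N[C@H]3CC[C@H](N)CC3)nc21`) gives 1800 nM and compound 2 (`CCCCn1cnc2c(NCc3cccc(Cl)c3)nc(N[C@H]3CC[C@H](N)CC3)nc21`) gives 4300 nM as the higher of the two numbers. This gap lies beyond the usual scatter, which makes compound 2 the weaker growth inhibitor of this pair.

Compound 3 (`CC(C)CCn1cnc2c(NCc3cccc(Cl)c3)nc(N[C@H]3CC[C@H](N)CC3)nc21`) differs from compound 2 by a single edit (methyl in place of hydrogen on a saturated chain carbon bound to two saturated chain carbons) that turns butyl into isopentyl: methyl in place of hydrogen on a saturated chain carbon bound to two saturated chain carbons. Within the data shown here, no measured pair shows this edit on its own, so the data offer no direct guide to its size. In this assay a single added methyl is expected to give no step beyond the scatter, with at most a slight lean toward a lower number, and the starting point remains compound 2 at 4300 nM as the anchor. The expected change is the estimated step of a 1.3-fold lower number from compound 2 to compound 3 (0.11 log units; within the scatter) and it stays small. Compound 3 is therefore estimated at 3300 nM with an expected range from 1500 nM to 7500 nM for repeated measurements.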

Compound 3, concentration for 50% growth inhibition: 3100 nM
Estimate against measurement, compound 3: 1.1-fold (0.03 log units) above; low and high end bracket the measured number.
By their numbers in this assay, from the lowest: compounds 1, 3 and 2 (each within the scatter of the next, the first and the last beyond it).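

Compound 3 differs from each of the two earlier compounds in one place only, so two changes that were previously mixed together can now be read separately. In this assay, methyl in place of hydrogen on a saturated chain carbon bound to two saturated chain carbons, which turns butyl into isopentyl, gives a 1.4-fold lower number from compound 2 to compound 3 (0.14 log units; within the scatter) and 3-chlorobenzyl in place of 4-chlorophenyl on a nitrogen on an aromatic ring gives a 1.7-fold higher number from compound 1 to compound 3 (0.24 log units; within the scatter) so neither change, taken alone, is shown to make a difference that stands out from the scatter. No other measurement is available to explain these two results.

On these data alone, the isopentyl and butyl chains are close in size, so it remains open what a much longer chain such as octyl, or a chain ending in an amine or a carboxylic acid, would do at this position. The second change also alters both the group on the nitrogen and where the chlorine sits, and 4-chlorobenzyl would be needed to read those two features apart.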